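Swapping the urea for a chlorinated amide

This account rests on a few compounds, and the source may have more. Where it says the series, first, only, none or still open, it means among the compounds named here.

Compound 1 `COc1cc(-c2nn(-c3cccc(NC(=O)c4cccc(C(F)(F)F)c4)c3)cc2-c2ccncc2)ccc1Cl` gives, in a functional assay on SN12C cells (Homo sapiens) for inhibition, read by sulforhodamine B assay, with a stated time of 48 h (on this read-out higher numbers stand for weaker inhibition of growth and lower numbers for stronger inhibition of growth), a value of > 50000 nM, which is a limit of the assay rather than a number. Compound 2 `COc1cc(-c2nn(-c3cccc(NC(=O)Nc4cccc(C(F)(F)F)c4)c3)cc2-c2ccncc2)ccc1Cl` carries a (3-(trifluoromethyl)phenyl)amino group on the carbonyl carbon where compound 1 has a 3-(trifluoromethyl)phenyl group, and in this assay compound 2 gives 21900 nM. That single change produced an at least 2.2-fold lower number from compound 1 to compound 2 (0.35 log units; beyond the scatter). Within the data shown here, compound 2 therefore holds the only actual number among the values shown; the other value is a limit (the limit of > 50000 nM in this assay, at which 1 of the 2 values shown sits). Compound 3 `COc1cc(-c2nn(-c3cccc(NC(=O)c4ccc(Cl)c(C(F)(F)F)c4)c3)cc2-c2ccncc2)ccc1Cl` differs from compound 2 by 4-chloro-3-(trifluoromethyl)phenyl in place of (3-(trifluoromethyl)phenyl)amino on a carbonyl carbon. Among the measured compounds shown here, this largely undoes the one measured step, returning from a urea to an amide, while the ring now carries a 4-chloro-3-(trifluoromethyl) pattern whose effect has not been measured. On that basis compound 3 is expected to show a higher number than compound 2, quite possibly reaching the limit again. The expected step is a 1.8-fold higher number from compound 2 to compound 3 (0.26 log units; within the scatter). Compound 3 is estimated at 40000 nM, within a range from 15000 nM to 100000 nM.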

Compound 3, concentration for total growth inhibition: > 32500 nM
Compound 3: only a limit was reported; the forecaster's own chance of this, stated with the estimate: 50%; the middle value lies beyond the limit too.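

Compound 3 reports a limit of the assay rather than a number in this assay: the limit of > 32500 nM in this assay, at which 1 of the 3 values shown sits.

Replacing the urea of compound 2 with an amide that also carries a chloro group gives an at least 1.4-fold higher number from compound 2 to compound 3 (0.17 log units; that floor lies within the scatter), so a real loss of growth inhibition is possible, but this floor alone does not establish one. As far as these compounds go, the step from compound 1 to compound 3, chloro in place of hydrogen on an aromatic carbon, cannot be read, as both compounds sit at limits, and the contribution of the chloro group on its own therefore remains unknown.

The compounds shown leave open whether a urea carrying the 4-chloro-3-(trifluoromethyl)phenyl group would give a lower number than compound 2, which would separate the effect of the ring pattern from that of the urea. They also leave open how a different group on the carbonyl carbon, such as a piperazine or a short alkoxy chain, would behave on the shared core.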